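This account rests on a few compounds, and the source may have more. Where it says the series, first, only, none or still open, it means among the compounds named here.

Compound 1 `CCc1ccc(NC(=S)N/N=C/c2cccs2)cc1` carries an ethyl group on an aromatic carbon of a six-membered aromatic ring of carbon only. In a functional assay on NCI/ADR-RES cells (Homo sapiens) for inhibition, read by sulforhodamine B assay, with a stated time of 48 h (a higher number here means a weaker inhibitor of growth, a lower number a stronger inhibitor of growth), compound 1 reaches only a limit of the assay, > 100000 nM, and no number. Compound 2 `C=CCNC(=S)N/N=C/c1cccs1` is the second substance with a result. In this assay compound 2 also reaches only a limit, > 100000 nM. Both results therefore sit at the limit of > 100000 nM in this assay, at which 2 of the 2 values shown sit, so compound 1 stands at the limit with nothing to rank it against. Among the measured compounds shown here, no pair of measured compounds differing in one place is available, so no measured step exists.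

Compound 3 `COc1ccc(NC(=S)N/N=C/c2cccs2)cc1` differs from compound 1 by methoxy in place of ethyl on an aromatic carbon. With nothing measured to guide the step, no shift beyond the scatter is expected in this assay, and the step that the limit leaves unreadable from compound 1 to compound 3 is estimated as essentially none. Compound 3 is expected to give about 150000 nM, most likely again as a limit, within a range from 50000 nM to 500000 nM.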

Compound 3, concentration for 50% growth inhibition: > 100000 nM
Compound 3 was reported as a limit; the forecaster's own chance of this, stated with the estimate: 80%; the middle value lies beyond the limit too.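

Compound 3, like compound 1, reaches only a limit in this assay, so the step between them cannot be read: the limit of > 100000 nM in this assay, at which 3 of the 3 values shown sit. The compounds shown leave open whether methoxy and ethyl differ at all in this assay; none of them yields a number.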